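A few compounds are considered here, and "the series" means these few. Any claim that something is new, unique, unknown or untested is made for them only; others in the source may bear on it.

Measured so far in a functional assay on U-251 cells (Homo sapiens); on this read-out lower numbers stand for stronger inhibition of growth and higher numbers for weaker inhibition of growth:
- compound 1 `COc1cc2ncnc(Nc3ccc(CS(=O)(=O)/C=C/c4ccc(Cl)cc4Cl)cc3)c2cc1OC`: 13000 nM
- compound 2 `COc1cc2ncnc(Nc3ccc(CS(=O)(=O)/C=C/c4ccc(F)cc4)cc3)c2cc1OC`: > 100000 nM (a limit of the assay, not a number)

Compound 2 has no number on this read-out: it stands at the limit of > 100000 nM in this assay, at which 1 of the 2 values shown sits. The next change leads to compound 3 `COc1cc2ncnc(Nc3ccc(CS(=O)(=O)/C=C/c4ccc(Br)cc4)cc3)c2cc1OC` and is bromo in place of fluoro on an aromatic carbon, para to a large group.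

For the measured compounds named here, one measured step bears on it: an at least 7.6-fold higher number from compound 1 to compound 2 (0.88 log units; beyond the scatter). This step lies beyond the scatter, and its true size is open since one end is a limit. Read in reverse, it shows that the only compound with a number, compound 1 at 13000 nM, carries a different halogen pattern from the 4-fluorophenyl of compound 2. A single pair sets no pattern, so the expectation is loose. A lower number than the limit of compound 2 is expected in this assay, probably not reaching far past compound 1.

The estimated step is an at least 2.8-fold lower number from compound 2 to compound 3 (0.45 log units; beyond the scatter). For compound 3 the expected value is 35000 nM, with an estimated range of 9000 nM to 100000 nM.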

Compound 3, concentration for 50% growth inhibition: 11000 nM
Compound 3: the middle estimate sits 3.2-fold (0.50 log units) above what was measured; low and high end bracket the measured number.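

In this assay, for the compounds shown here, the group para to a large group on this aromatic ring decides whether the read-out gives a number at all: an at least 9.0-fold lower number from compound 2 to compound 3 (0.95 log units; beyond the scatter), with bromo in place of fluoro as the only change. As far as these compounds go, compound 2 stands at a limit of the assay rather than at a number, so the true size of this step stays open: the limit of > 100000 nM in this assay, at which 1 of the 3 values shown sits. The second comparison, a 1.2-fold lower number from compound 1 to compound 3 (0.07 log units; within the scatter), puts the 4-bromophenyl of compound 3 level with the 2,4-dichlorophenyl of compound 1, so a single bromo at this place is enough to match the two chloro groups on this read-out.

From the compounds shown here alone, it remains open whether fluoro alone stands apart or whether a chloro, iodo or methoxy group at the same place would also give a number close to these two. Going by these compounds, it is also open whether a trifluoromethyl group or a nitrile here would move the read-out clearly away from the level of compound 3, 11000 nM, in this assay.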